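The source may report more compounds than this note shows. Statements on the series, on what has been measured and on what is new or still open speak of the compounds shown alone.

Measured so far:
- compound 1 `CN(C[C@H]1Cc2c(cccc2N2CCN(Cc3ccccn3)CC2)CN1)[C@H]1CCCc2cccnc21`: 4.2%
- compound 2 `C[C@@H]1CN(c2cccc3c2C[C@H](CN(C)[C@H]2CCCc4cccnc42)NC3)C[C@H](C)N1`: 100%
- compound 3 `Cc1cnc2c(c1)CCC[C@@H]2N(C)C[C@H]1Cc2c(cccc2N2CCNCC2)CN1`: 47.8%

In an ADME assay on microsomes from liver (Homo sapiens) for metabolic stability, read by LC-MS, with a stated time of 10 min (a higher number here means that more of the compound is left, a lower number that less of the compound is left), compound 3 stands second highest of the three numbers: compound 1 lies well below it, beyond the scatter, and compound 2 lies well above it, also beyond the scatter. Compound 4 `CN(C[C@H]1Cc2c(cccc2N2CCNCC2)CN1)[C@H]1CCCc2cccnc21` has not yet been measured in this assay. It differs from compound 3 in one place: hydrogen in place of methyl on an aromatic carbon. Among the compounds with values here, no pair of measured compounds shows a step of this kind, so the size of the change cannot be read from the data; the estimate rests on the number for compound 3 alone. A small step is expected, upward if at all, and probably not beyond the scatter a number 7.2 percentage points higher from compound 3 to compound 4 (within the scatter). For compound 4 a value of 55% is estimated, within a range of 25% to 85%.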

Compound 4, percent of the compound remaining: 99.7%
For compound 4 the middle estimate is 44.7 percentage points below the measured one, outside the stated range (above it).
By their numbers in this assay, from the lowest: compound 1; then compound 3; then compounds 4 and 2 (each within the scatter of the next).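

Hydrogen in place of methyl on the aromatic carbon, two atoms from the ring nitrogen, gives a number 51.9 percentage points higher from compound 3 to compound 4 (beyond the scatter) in this assay, so this single position matters far more than the earlier compounds could show. Piperazin-1-yl in place of 3,5-dimethylpiperazin-1-yl goes with a number 0.3 percentage points lower from compound 2 to compound 4 (within the scatter) and changes nothing that can be told from the scatter. Hydrogen in place of (pyridin-2-yl)methyl on an amine nitrogen in a ring gives a number 95.5 percentage points higher from compound 1 to compound 4 (beyond the scatter) as the largest step here.

No measurement is available that accounts for these steps. As far as these compounds go, whether fluorine, chlorine or a methoxy group on that aromatic carbon would follow methyl or hydrogen remains open.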